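A few compounds are considered here, and "the series" means these few. Any claim that something is new, unique, unknown or untested is made for them only; others in the source may bear on it.

In a physicochemical assay for solubility, read by HPLC, in phosphate buffer, at pH 6.5 (a higher number here means a more soluble compound, a lower number a less soluble compound), compound 1 (`COC(=O)C1=C(C)NC(c2nccs2)=NC1(C)c1ccc(F)cc1`) gives 22 ug/mL and compound 2 (`COC(=O)C1=C(CN2CC3CC2CO3)NC(c2nccs2)=NC1(C)c1ccc(F)cc1`) gives 564 ug/mL as the higher of the two numbers. The next compound is compound 3 (`COC(=O)C1=C(CN2CCC(O)CC2)NC(c2nccs2)=NC1(C)c1ccc(F)cc1`), and the structural change from compound 2 is a group of 7 heavy atoms (5 carbon, 1 nitrogen, 1 oxygen; one six-membered non-aromatic ring with 1 hetero atom) in place of a group of 7 heavy atoms (5 carbon, 1 nitrogen, 1 oxygen; 2 five-membered non-aromatic rings with 1 hetero atom each), on a saturated chain carbon bound to a double-bonded ring carbon in this series. Going by the values given here, the one measured step bearing on this is a 26-fold higher number from compound 1 to compound 2 (1.41 log units; beyond the scatter) and it is large, but it puts a group in place of a hydrogen atom, whereas here one group replaces another on the same saturated chain carbon. No exchange of two such groups has been measured, so the data give no direction for it. No step beyond the scatter is therefore expected in this assay for this change. The estimated step is a 1.1-fold higher number from compound 2 to compound 3 (0.03 log units; within the scatter) on present data. For compound 3 the expected value is 600 ug/mL with an expected range from 200 ug/mL to 1500 ug/mL in this read-out.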

Compound 3, solubility: 593 ug/mL
Beside the measured number, compound 3's estimate is 1.0-fold (0.01 log units) above it; low and high end bracket the measured number.
By their numbers in this assay, from the lowest: compound 1; then compounds 2 and 3 (each within the scatter of the next).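

In this assay, the two groups with the same heavy-atom count but different ring forms, one with 2 five-membered non-aromatic rings and the other 4-hydroxypiperidin-1-yl, are not told apart at this saturated chain carbon: the exchange gives a 1.1-fold higher number from compound 2 to compound 3 (0.02 log units; within the scatter) in this read-out. The large step from hydrogen is therefore not confined to a single group, since 4-hydroxypiperidin-1-yl in place of hydrogen gives a 27-fold higher number from compound 1 to compound 3 (1.43 log units; beyond the scatter) and joins a 26-fold higher number from compound 1 to compound 2 (1.41 log units; beyond the scatter) as a second such step at this place. No measurement at hand accounts for the size of these steps or for the absence of a separation between the two groups.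

From the compounds shown here alone, both groups contain 1 nitrogen and 1 oxygen, so the part played by the oxygen stays open. Piperidin-1-yl, a dimethylamino group or a piperidine bearing a carboxylic acid would each test how far the step from hydrogen carries over to a different set of atoms.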